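This account rests on a few compounds, and the source may have more. Where it says the series, first, only, none or still open, it means among the compounds named here.

Measured compounds in a functional assay for inhibition, with Homo sapiens as the target; on this read-out lower numbers stand for stronger inhibition and higher numbers for weaker inhibition:
compound 1 `C=CCn1ncc2cncn2c1=O` — > 48000 nM
compound 2 `C=CCn1ncc2cnc(C)n2c1=O` — > 48000 nM
compound 3 `CCOC(=O)Cn1ncc2cnc(COC)n2c1=O` — > 48000 nM

Compound 3 `CCOC(=O)Cn1ncc2cnc(COC)n2c1=O` stands in this assay only at a limit, > 48000 nM, not at a number. Compound 1 likewise returns only the limit > 48000 nM in this assay. Compound 2 also gives only the limit > 48000 nM. Among the measured compounds shown here, the one change that can be compared, methyl in place of hydrogen on an aromatic carbon, is a step that the two limits leave unreadable from compound 1 to compound 2; it cannot be read, since the limit of > 48000 nM in this assay, at which 3 of the 3 values shown sit, is where every value of the series sits.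

The not-yet-measured compound 4 `C=CCn1ncc2cnc(COC)n2c1=O` differs from compound 3 by vinyl in place of ethoxycarbonyl on a saturated chain carbon bound to an aromatic nitrogen. For the measured compounds named here, no measured pair shows this particular change, so no step of known size bears on it directly. What does bear on it is that the allyl compounds 1 and 2 and the ester compound 3 all rest at the same limit in this assay, so a change of this kind within the series has nowhere yet produced a readable number.

Compound 4 is therefore expected to stay at or near the limit as well, with an estimated step that the limit leaves unreadable from compound 3 to compound 4. The estimate for compound 4 in this assay is 60000 nM, expected within 20000 nM to 200000 nM.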

Compound 4, half-maximal inhibitory concentration: > 48000 nM
Compound 4 ended at the assay's limit (the forecaster's own chance of this, stated with the estimate: 85%); the middle value does not contradict the limit.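

In this assay compound 4 gives > 48000 nM as a limit and not a number. The steps from compound 1, compound 2 and compound 3 to compound 4 therefore cannot be read, and the series stays where it stood: the limit of > 48000 nM in this assay, at which 4 of the 4 values shown sit.

The compounds shown leave open whether any change on the shared core brings a readable number in this assay at all.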